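The source may report more compounds than this note shows. Statements on the series, on what has been measured and on what is new or still open speak of the compounds shown alone.

Values from a functional assay on A549 cells (Homo sapiens) for antiproliferative activity, read by MTT assay, with a stated time of 72 h (a lower number here means a stronger inhibitor, a higher number a weaker inhibitor), stand as follows:

- compound 1 `C=CC(=O)Nc1cccc(Oc2nc(Nc3ccn(C)n3)nc3c2CSCC3)c1` gives 18600 nM
- compound 2 `CC(C)=CC(=O)Nc1cccc(Oc2nc(Nc3ccn(C)n3)nc3c2CSCC3)c1` gives 44200 nM
- compound 3 `C=CC(=O)Nc1cccc(Oc2nc(Nc3cccc(OC)c3)nc3c2CSCC3)c1` gives 10100 nM

Compound 3 cannot be told apart from compound 1 (a 1.8-fold lower number from compound 1 to compound 3 (0.27 log units; within the scatter)), and its number is lower than that of compound 2 (44200 nM). Compound 4 `CC/C=C/C(=O)Nc1cccc(Oc2nc(Nc3cccc(OC)c3)nc3c2CSCC3)c1` carries but-1-en-1-yl in place of vinyl on the carbonyl carbon of compound 3 (but-1-en-1-yl in place of vinyl on a carbonyl carbon). The closest guide is the step (a 2.4-fold higher number from compound 1 to compound 2 (0.38 log units; beyond the scatter)) in which 2-methylprop-1-en-1-yl replaced vinyl on that same carbonyl carbon. The other measured step (a 1.8-fold lower number from compound 1 to compound 3 (0.27 log units; within the scatter)) changes a different part and says little here. Resting on that single example, the expectation in this assay is a similar modest rise (a 2.2-fold higher number from compound 3 to compound 4 (0.34 log units; beyond the scatter)). Compound 4 is estimated at 22000 nM (expected range 10000 nM to 50000 nM).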

Compound 4, half-maximal inhibitory concentration: 17200 nM
Compound 4: middle estimate off by 1.3-fold (0.11 log units), on the high side; low and high end bracket the measured number.
By their numbers in this assay, from the lowest: compounds 3, 4 and 1 (each within the scatter of the next); then compound 2.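

In this assay, lengthening the group on the carbonyl carbon from vinyl to but-1-en-1-yl leaves the number within the scatter (a 1.7-fold higher number from compound 3 to compound 4 (0.23 log units; within the scatter)). So a change at this position need not shift the number measurably, whereas the only earlier change here, to 2-methylprop-1-en-1-yl, went beyond the scatter (a 2.4-fold higher number from compound 1 to compound 2 (0.38 log units; beyond the scatter)). That earlier step, however, was taken with a different group on the nitrogen on the aromatic ring.

Still open, as far as these compounds go, is whether a longer chain or an amine on the but-1-en-1-yl group would keep this number. Nothing measured here explains the size of either step.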